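A few compounds are considered here, and "the series" means these few. Any claim that something is new, unique, unknown or untested is made for them only; others in the source may bear on it.

Measured compounds:
compound 1 `CCCCCC/N=C(\C)c1c(O)c2ccccc2oc1=O` gives 2900 nM in an assay on isolated protein for inhibition of myosin-2 (Bos taurus), read by spectrophotometry, with a stated time of 24 min; on this read-out lower numbers stand for stronger inhibition and higher numbers for weaker inhibition
compound 2 `CCC(C)/N=C(\C)c1c(O)c2ccccc2[nH]c1=O` gives >= 100000 nM in this assay, which is a limit of the assay and not a number

Within the data shown here, compound 1 stands as the only compound in this assay with a measured number. Compound 2 sits at the limit, as stated in the limit of >= 100000 nM in this assay, at which 1 of the 2 values shown sits. Among the measured compounds shown here, compound 2 differs from compound 1 in more than one place, so no single step between them can be read; the two values only show that compound 1 gives a number where compound 2 gives none.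

The next compound, compound 3 `C/C(=N\Cc1ccc(C)cc1)c1c(O)c2ccccc2oc1=O`, is not yet measured. Its change from compound 1 is 4-methylphenyl in place of pentyl on a saturated chain carbon bound to a double-bonded nitrogen. For the measured compounds named here, no measured step of this kind is available, so the size of the change in this assay is uncertain; the expectation is for a step of about the scatter or a little beyond, in no firm direction, leaning toward no change.

On that basis compound 3 is expected to give 3000 nM in this assay, within 800 nM to 12000 nM. The step expected a 1.0-fold higher number from compound 1 to compound 3 (0.01 log units; within the scatter) is estimated as small.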

Compound 3, half-maximal inhibitory concentration: 7900 nM
Compound 3: the middle estimate sits 2.6-fold (0.42 log units) below what was measured; measured number inside the range.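

Working from this assay, the saturated chain carbon bound to a double-bonded nitrogen now has its first readable step: a 2.7-fold higher number from compound 1 to compound 3 (0.44 log units; beyond the scatter), with 4-methylphenyl in place of pentyl. This position therefore accepts an aromatic ring of carbon only and still gives a measured number, so a ring here does not carry the series to a limit of the assay, although the step is beyond the scatter and modest in size. No measured property at hand accounts for this step, and a single step cannot separate the presence of the ring from the change in heavy-atom count between the two groups.

Steps to compound 2 cannot be read, as it differs from both other compounds in more than one place and its value is a limit of the assay. Still open, as far as these compounds go, is how this position responds to an unsubstituted phenyl, a longer chain such as octyl, or a group of another kind such as an amine or a carboxylic acid, and whether the modest step from pentyl to 4-methylphenyl holds for any of these.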